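This account rests on a few compounds, and the source may have more. Where it says the series, first, only, none or still open, it means among the compounds named here.

Measured so far in an ADME assay on J774.1 cells (Mus musculus) for cytotoxicity, with a stated time of 48 h; on this read-out lower numbers stand for an effect already at smaller amounts and higher numbers for an effect only at larger amounts of compound:

compound 1 `CC[C@@H]1CC2(C[C@@H](CC)N1)C(=O)NC(=O)N2Cc1ccccc1` — > 100 uM, a limit of this assay.
compound 2 `CCOC(=O)C1C(=O)C(C(=O)OCC)[C@H](c2ccc([N+](=O)[O-])cc2)N(Cc2ccccc2)[C@@H]1c1ccc([N+](=O)[O-])cc1` — > 100 uM, a limit of this assay.
compound 3 `COC(=O)C1C(=O)C(C(=O)OC)[C@H](c2cccc([N+](=O)[O-])c2)N(Cc2ccccc2)[C@@H]1c1cccc([N+](=O)[O-])c1` — > 100 uM, a limit of this assay.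

Where compound 3 stands: in this assay compound 3 reports only a limit, not a number, and the same holds for the two other values, so no order among the three can be read; the whole set sits at the point described by the limit of > 100 uM in this assay, at which 3 of the 3 values shown sit.

The next compound in the series is compound 4 `COC(=O)C1C(=O)C(C(=O)OC)[C@H](c2cccc([N+](=O)[O-])c2)N(Cc2ccc(Cl)cc2)[C@@H]1c1cccc([N+](=O)[O-])c1`. It differs from compound 3 in one place: chloro in place of hydrogen on an aromatic carbon. The shared core, the two nitrophenyl groups and both methyl esters are kept, and only the benzyl on the ring nitrogen becomes a 4-chlorobenzyl.

Going by the values given here, no step between measured compounds in this assay can be computed, since every value is a limit. Compound 4 is therefore expected to stay where compound 3 sits, and the step of a number no higher from compound 3 to compound 4 (the limit leaves the size open) is estimated as none beyond the scatter, because the limit of > 100 uM in this assay, at which 3 of the 3 values shown sit, is the only point the series has shown. For compound 4 in this assay the estimate is 100 uM, with a range from 40 uM to 300 uM, and most likely again only a limit will be reported.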

Compound 4, concentration for half-maximal effect: 46.6 uM
Compound 4: middle estimate off by 2.1-fold (0.33 log units), on the high side, and the stated range covers the measured number.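

In this assay, going by these compounds alone, compound 4 is the first of the series to give a number rather than a limit, and the only change is chloro in place of hydrogen on an aromatic carbon of the benzyl group, which gives an at least 2.1-fold lower number from compound 3 to compound 4 (0.33 log units; beyond the scatter). Going by these compounds, compound 3 reports > 100 uM, which is a limit, so the true size of this step stays open and only its lower bound can be read. This single added atom is enough to move the series away from the only point it had shown until now: the limit of > 100 uM in this assay, at which 3 of the 4 values shown sit.

Whether this step is specific to chloro stays open, as the compounds shown include no fluoro, bromo, methyl or methoxy group at the same place on the benzyl, and no chloro at another place on that ring. Also open is whether the same change would give a similar step with the ethyl esters of compound 2 or on the core of compound 1, since neither has a 4-chlorobenzyl counterpart among the compounds shown.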